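The compounds below may be only part of what the source reports. "The series", "measured", "known", "first", "only" and "open" are said of these compounds alone.

Working notes on the series, read in a functional assay on A549 cells (Homo sapiens) for cytotoxicity, read by MTT assay, with a stated time of 72 h; a higher number here means a weaker inhibitor, a lower number a stronger inhibitor. Compound 1 `CC(C)(C)C1=CC(=O)C=C(NCCC(=O)O)C1=O` gives 171000 nM, and compound 3 `CC(C)(C)C1=CC(=O)C=CC1=O` gives 47000 nM. For compound 2 `CC(C)(C)C1=CC(=O)C=C(NCC(=O)O)C1=O`, > 200000 nM is a limit and not a number. Compound 4 `CC(C)[C@@H](NC1=CC(=O)C=C(C(C)(C)C)C1=O)C(=O)O` has isopropyl in place of hydrogen on a saturated chain carbon bound to an amine nitrogen and a carbonyl carbon. The nearest measured change on the chain is an at least 1.1-fold higher number from compound 1 to compound 2 (0.06 log units; that floor lies within the scatter), within the scatter. Removing the whole substituent gives only modest steps: a 3.6-fold lower number from compound 1 to compound 3 (0.56 log units; beyond the scatter) and an at least 4.2-fold lower number from compound 2 to compound 3 (0.62 log units; beyond the scatter). No step beyond the scatter is therefore expected in this assay, with any shift toward a lower number. The estimated step is an at least 1.3-fold lower number from compound 2 to compound 4 (0.12 log units; that floor lies within the scatter). For compound 4 the expected value is 150000 nM, with an estimated range of 70000 nM to 300000 nM.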

Compound 4, half-maximal inhibitory concentration: 154000 nM
The estimate for compound 4 lay 1.0-fold (0.01 log units) below the measured number; measured number inside the range.
By their numbers in this assay, from the lowest: compound 3; then compounds 4 and 1 (each within the scatter of the next). At a limit, above all of these: compound 2.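

In this assay, isopropyl in place of hydrogen on a saturated chain carbon bound to an amine nitrogen and a carbonyl carbon gives an at least 1.2-fold lower number from compound 2 to compound 4 (0.11 log units; that floor lies within the scatter). Compound 4 shows that this carbon can carry isopropyl and still give a measured number, 154000 nM. The value for compound 2 is a limit and not a number, so the step is only a floor and its true size stays unread: the limit of > 200000 nM in this assay, at which 1 of the 4 values shown sits.

Open, as far as these compounds go, is whether benzyl on this same carbon, or a primary amide in place of the carboxylic acid, would move the number toward that of compound 3, 47000 nM.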